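A few compounds are considered here, and "the series" means these few. Any claim that something is new, unique, unknown or untested is made for them only; others in the source may bear on it.

Of the compounds shown here, three with a shared core have been tested in a functional assay on BMEC cells (Bos taurus) for antiproliferative activity; a higher number here means a weaker inhibitor, a lower number a stronger inhibitor. Compound 1 `COc1cc(/C=C\Cc2cc(O)c3ccsc3c2)cc(OC)c1OC` gives 87 nM. Compound 2 `COc1cc(/C=C\Cc2cc(O)c3ccoc3c2)cc(OC)c1OC` has a core that differs from that of compound 1 in a way that is not broken down here; in this assay compound 2 gives 49 nM. The value of compound 2 and that of compound 1 lie within the usual scatter of each other. Compound 3 `COc1cc(/C=C\Cc2cc(O)c3cc(C)sc3c2)cc(OC)c1OC`, which carries a methyl in place of hydrogen on an aromatic carbon, gives 23 nM in this assay.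

Among the compounds with values here, the one step that can be followed directly is the change from compound 1 to compound 3. Its structural description is methyl in place of hydrogen on an aromatic carbon, and it produced a 3.8-fold lower number from compound 1 to compound 3 (0.58 log units; beyond the scatter).

Compound 4 `COc1cc(/C=C\Cc2cc(O)c3cc(C)oc3c2)cc(OC)c1OC` has not yet been measured in this assay. It differs from compound 2 by methyl in place of hydrogen on an aromatic carbon. Within the data shown here, the change is of the same kind as the one from compound 1 to compound 3, not the same: in compound 4 the methyl sits on a five-membered aromatic ring with 1 oxygen, next to the ring oxygen, whereas in compound 3 it sits on a five-membered aromatic ring with 1 sulfur, next to the ring sulfur.

Because the earlier methyl gave a 3.8-fold lower number from compound 1 to compound 3 (0.58 log units; beyond the scatter), a step of similar size is expected here, namely a 3.5-fold lower number from compound 2 to compound 4 (0.54 log units; beyond the scatter). Starting from compound 2, compound 4 is therefore estimated at 14 nM in this assay, with a plausible span from 6 nM to 40 nM.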

Compound 4, half-maximal inhibitory concentration: 93 nM
For compound 4 the middle estimate is 6.6-fold (0.82 log units) below the measured one; measured number above the stated range.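

In this assay, putting a methyl in place of hydrogen on an aromatic carbon, next to the ring oxygen, gives a 1.9-fold higher number from compound 2 to compound 4 (0.28 log units; within the scatter), so on this core the methyl leaves no effect that can be told apart from the ordinary variation between repeat measurements. The earlier methyl step on the sulfur-containing core therefore does not carry over to the oxygen-containing core, and a gain seen on one core in this series cannot simply be assumed on the other: the same change on two cores in this assay, a 3.8-fold lower number (0.58 log units; beyond the scatter) from compound 1 to compound 3 and a 1.9-fold higher number (0.28 log units; within the scatter) from compound 2 to compound 4, 7.2-fold (0.86 log units) apart, beyond the scatter of two such steps. Within the data shown here, this does not show why the two cores part ways, nor that the result is general, since each core offers only one such pair, and the data cannot tell whether the ring oxygen and ring sulfur themselves account for the gap.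

The compounds shown carry only hydrogen or methyl on this carbon, so it remains open how a longer chain such as ethyl, a chlorine atom or an amine would behave there. Going by these compounds, it also remains open whether such groups would show the same gap between the two cores or would act alike on both.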